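The compounds below may be only part of what the source reports. "The series", "measured", "known", "first", "only" and "open" are said of these compounds alone.

Three compounds of the series carry numbers in a functional assay on PC-3 cells (Homo sapiens) for antiproliferative activity, read by MTT assay, with a stated time of 72 h; a higher number here means a weaker inhibitor, a lower number a stronger inhibitor. Compound 1 `C/C=C/C(=O)Nc1cc2c(N3CCCc4ccccc43)ncnc2cc1O[C@@H]1CCOC1` gives 9350 nM, compound 2 `CC/C=C/C(=O)Nc1cc2c(N3CCCc4ccccc43)ncnc2cc1O[C@@H]1CCOC1` gives 14300 nM, and compound 3 `CN(C)C/C=C/C(=O)Nc1cc2c(N3CCc4ccccc43)ncnc2cc1O[C@@H]1CCOC1` gives 1230 nM. Compound 3 stands lowest of the three, separated from both compound 1 and compound 2 by more than the scatter. For the measured compounds named here, the single matched step among the measured compounds is a 1.5-fold higher number from compound 1 to compound 2 (0.18 log units; within the scatter), a change on the chain and not on the ring attached to the shared core.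

Compound 4 `CN(C)C/C=C/C(=O)Nc1cc2c(N3CCCc4ccccc43)ncnc2cc1O[C@@H]1CCOC1` differs from compound 3 by 1,2,3,4-tetrahydroquinolin-1-yl in place of 2,3-dihydro-1H-indol-1-yl on an aromatic carbon. Going by the values given here, no measured pair shows this particular exchange, so nothing in the set bears directly on it; the step from compound 1 to compound 2 concerns a different part of the molecule and gives no guidance on the ring. In the absence of a matched pair, no move beyond the scatter is expected, and the expected step is a 1.5-fold higher number from compound 3 to compound 4 (0.17 log units; within the scatter). Compound 4 is accordingly estimated at 1800 nM in this assay, with a range from 600 nM to 6000 nM.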

Compound 4, half-maximal inhibitory concentration: 4170 nM
Compound 4: the middle estimate sits 2.3-fold (0.36 log units) below what was measured; low and high end bracket the measured number.
By their numbers in this assay, from the lowest: compound 3; then compound 4; then compounds 1 and 2 (each within the scatter of the next).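

In this assay, for the compounds shown here, this is the first reading of a ring exchange on the aromatic carbon next to the ring nitrogen: 1,2,3,4-tetrahydroquinolin-1-yl in place of 2,3-dihydro-1H-indol-1-yl gives a 3.4-fold higher number from compound 3 to compound 4 (0.53 log units; beyond the scatter) and so separates the two rings on the same chain. With 1,2,3,4-tetrahydroquinolin-1-yl held, dimethylamino on the saturated chain carbon gives a 3.4-fold lower number from compound 2 to compound 4 (0.54 log units; beyond the scatter) where methyl stood and a 2.2-fold lower number from compound 1 to compound 4 (0.35 log units; beyond the scatter) where hydrogen stood, so this chain position also moves the number, which the step between compound 1 and compound 2 did not show. No measurement shown here offers an explanation for these steps.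

Going by these compounds, whether the ring step keeps its size with methyl or hydrogen on the chain remains open. On these data alone, how diethylamino or a longer chain would read at the dimethylamino position also remains open.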